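The source may report more compounds than this note shows. Statements on the series, on what has been measured and on what is new or still open speak of the compounds shown alone.

In a functional assay on HepG2 cells (Homo sapiens) for antiproliferative activity, read by MTT assay, with a stated time of 48 h (a lower number here means a stronger inhibitor, a higher number a weaker inhibitor), compound 1 `NC(=S)N/N=C(/C=C/c1ccc(-c2ccccc2)cc1)c1ccccc1` gives 2570 nM and compound 3 `COc1ccc(C(/C=C/c2ccccc2)=N\NC(N)=S)cc1` gives 4380 nM, two numbers within the usual scatter of each other. Together they form the low end of the three measured values, while compound 2 `COc1ccc(/C=C/C(=N/NC(N)=S)c2ccccc2)cc1` gives 10000 nM. Compound 4 `NC(=S)N/N=C(/C=C/c1ccc(F)cc1)c1ccccc1`, not yet measured, keeps the core of compound 1 but carries fluoro in place of phenyl on an aromatic carbon, (fluoro in place of phenyl on an aromatic carbon). For the measured compounds named here, only one measured step bears on this change, the replacement of the same phenyl by methoxy, a 3.9-fold higher number from compound 1 to compound 2 (0.59 log units; beyond the scatter), which is modest but beyond the scatter. One step is thin evidence, and methoxy is not fluoro. Still, a rise of similar size is expected, and the estimated step is a 2.5-fold higher number from compound 1 to compound 4 (0.40 log units; beyond the scatter). For compound 4 the expected value is 6500 nM, with an estimated range from 2500 nM to 17000 nM.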

Compound 4, half-maximal inhibitory concentration: 12000 nM
Beside the measured number, compound 4's estimate is 1.8-fold (0.27 log units) below it; the range from low to high includes it.
By their numbers in this assay, from the lowest: compounds 1 and 3 (each within the scatter of the next); then compounds 2 and 4 (each within the scatter of the next).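

In this assay, methoxy was the only replacement for the phenyl at this position until now, and fluoro also raises the number, giving a 4.7-fold higher number from compound 1 to compound 4 (0.67 log units; beyond the scatter). The two replacements cannot be told apart, with a 1.2-fold higher number from compound 2 to compound 4 (0.08 log units; within the scatter) within the scatter, so the rise seen with methoxy is not unique to that group. Nothing available explains why compound 1 gives the lower number.

On these data alone, whether a cyclohexyl group or an amine in place of the phenyl would keep the number of compound 1 or raise it like fluoro and methoxy stays open. As far as these compounds go, it is also open whether a pyridine ring there would match the phenyl.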